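Moving the fluorine: from compound 2 to compound 4

The compounds below may be only part of what the source reports. "The series", "measured", "known", "first", "only" and "open" are said of these compounds alone.

Measured so far in a functional assay on NCI-H460 cells (Homo sapiens) for inhibition, read by MTT assay, with a stated time of 72 h; on this read-out lower numbers stand for stronger inhibition and higher numbers for weaker inhibition
Compound 1 `Cc1nc(-c2ccccc2F)c(C(=O)N2CCN(c3cc(Cl)cc(Cl)c3)CC2)o1` gives 165 nM
Compound 2 `COc1cc(OC)cc(N2CCN(C(=O)c3oc(C)nc3-c3ccccc3F)CC2)c1` gives 42 nM
Compound 3 `CCC[C@H](Nc1nc(-c2ccc(NC(=O)NCC)c(OC)c2)ncc1C)c1cccnc1` gives 272 nM

Compound 2 has the lowest number of the three, and the other two lie beyond the scatter from it. Compound 4 `COc1cc(OC)cc(N2CCN(C(=O)c3oc(C)nc3-c3cccc(F)c3)CC2)c1` has not yet been measured and differs from compound 2 in one place: 3-fluorophenyl in place of 2-fluorophenyl on an aromatic carbon. Here, 3-fluorophenyl stands in place of 2-fluorophenyl on an aromatic carbon. Going by the values given here, the only measured step, a 3.9-fold lower number from compound 1 to compound 2 (0.59 log units; beyond the scatter), was modest and changed a different place, so no measured step moves the fluorine. Among the compounds with values here, compound 3 offers no step at all. A small step towards a higher number is therefore expected in this assay, though one within the scatter would be no surprise. The expected change is a 1.5-fold higher number from compound 2 to compound 4 (0.19 log units; within the scatter) in this estimate. Compound 4 is estimated at 65 nM with an expected range of 22 nM to 190 nM in this assay.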

Compound 4, half-maximal inhibitory concentration: 67 nM
For compound 4 the middle estimate is 1.0-fold (0.01 log units) below the measured one; the range from low to high includes it.
By their numbers in this assay, from the lowest: compounds 2 and 4 (each within the scatter of the next); then compounds 1 and 3 (each within the scatter of the next).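

In this assay, going by these compounds alone, a 1.6-fold higher number from compound 2 to compound 4 (0.20 log units; within the scatter) is the first measured step at this aromatic carbon of the five-membered ring. At this place the assay therefore does not separate 2-fluorophenyl from 3-fluorophenyl, whereas the earlier step concerned the group on the amine nitrogen. No measurement shown here offers an explanation for this result.

As far as these compounds go, whether a plain phenyl or a pyridine ring at the same carbon would stay within the scatter of these two remains open. So does whether 3-fluorophenyl behaves alike alongside 3,5-dichlorophenyl on the amine nitrogen.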